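This account rests on a few compounds, and the source may have more. Where it says the series, first, only, none or still open, it means among the compounds named here.

Within the data shown here, compound 1 `O=C(/C=C\Nc1ccc(F)cc1)c1nc(-c2ccc(F)cc2)n2ccccc12` is the only compound with a number in a functional assay on BT-474 cells (Homo sapiens) for cytotoxicity, read by MTT assay, with a stated time of 48 h (on this read-out higher numbers stand for weaker inhibition and lower numbers for stronger inhibition), where compound 1 gives 16900 nM. Compound 2 `O=C(/C=C\Nc1ccc(F)cc1)c1nc(-c2ccc(C(F)(F)F)cc2)n2ccccc12` reaches only a limit of the assay, giving > 30000 nM in this assay. Among the measured compounds shown here, the one measured step, an at least 1.7-fold higher number from compound 1 to compound 2 (0.24 log units; that floor lies within the scatter), concerns a different part of the structure than the change to compound 3 `O=C(/C=C\Nc1ccc(Cl)cc1)c1nc(-c2ccc(F)cc2)n2ccccc12`, which is chloro in place of fluoro on an aromatic carbon. For the measured compounds named here, no measured step bears directly on that change, so nothing beyond the scatter is expected in this assay, and the step is estimated as a 1.0-fold higher number from compound 1 to compound 3 (0.00 log units; within the scatter). Compound 3 is therefore expected to give about 17000 nM, between 7000 nM and 35000 nM.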

Compound 3, half-maximal inhibitory concentration: 7030 nM
The estimate for compound 3 lay 2.4-fold (0.38 log units) above the measured number, and the stated range covers the measured number.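

In this assay, chloro on the (4-chlorophenyl)amino group in place of fluoro gives a 2.4-fold lower number from compound 1 to compound 3 (0.38 log units; beyond the scatter), showing that this position responds to an exchange of one halogen for another. Among these compounds, the only earlier step, an at least 1.7-fold higher number from compound 1 to compound 2 (0.24 log units; that floor lies within the scatter), concerns the other 4-fluorophenyl group and ends at a limit of the assay. Nothing shown here gives a reason for the new step. On these data alone, whether bromo, methyl, methoxy or an amine at this position would lower the number further stays open, as does the effect of chloro on the other 4-fluorophenyl group.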